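The source may report more compounds than this note shows. Statements on the series, on what has been measured and on what is new or still open speak of the compounds shown alone.

Compound 1 `CCNC(=O)c1noc(-c2cc(C(C)C)c(O)cc2O)c1-c1cc(CNC)no1` stands as "not determined" (no result reported) in a functional assay on A2780 cells (Homo sapiens) for inhibition; a lower number here means a stronger inhibitor, a higher number a weaker inhibitor: no single number marks where it stands. A closely related compound 2 `CCNC(=O)c1noc(-c2cc(C(C)C)c(O)cc2O)c1-c1cc(C(N)=O)no1` has been measured, and in this assay compound 2 gives 15 nM. Compound 3 `CCNC(=O)c1noc(-c2cc(C(C)C)c(O)cc2O)c1-c1ccn(C(C)C)n1` has not been measured yet. It arises from compound 1 by a single exchange at one aromatic carbon of the shared core (1-isopropyl-1H-pyrazol-3-yl in place of 3-((methylamino)methyl)-1,2-oxazol-5-yl on an aromatic carbon), so that a group carrying 1 hydrogen-bond donor and 3 hydrogen-bond acceptors gives way to one carrying 0 hydrogen-bond donors and 2 hydrogen-bond acceptors, the count of heavy atoms staying the same. Within the data shown here, since compound 1 has no number, no step from it can be sized, and no direction for the exchange can be read from the compounds measured so far. Resting on compound 2 and its value of 15 nM, compound 3 is expected to fall near 30 nM, within a range from 8 nM to 150 nM.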

Compound 3, half-maximal inhibitory concentration: 45 nM
For compound 3 the middle estimate is 1.5-fold (0.18 log units) below the measured one, within the range that was stated.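

In this assay, placing 1-isopropyl-1H-pyrazol-3-yl on this aromatic carbon in place of 3-carbamoyl-1,2-oxazol-5-yl gives a 3.0-fold higher number from compound 2 to compound 3 (0.48 log units; beyond the scatter), a modest but real loss. The entering group carries 0 hydrogen-bond donors, yet compound 3 still gives 45 nM, so inhibition at this level does not depend on a donor in the group at this position. No measurement at hand accounts for the size of the step.

Among these compounds, compound 1 has no number, so no step from it can be read, and what its 3-((methylamino)methyl)-1,2-oxazol-5-yl group does in this assay stays open. Also open, on these data alone, is how a carboxylic acid in place of the carbamoyl group, or a longer chain in place of the isopropyl group, would fare.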